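The source may hold more compounds than are shown below. What is called first, only, known or untested is meant among the compounds shown, and "the series" means these compounds.

Of the compounds shown here, two have been measured so far. Compound 1, `COc1cc(C(=O)/C=C/c2c(-c3cccs3)nc3ccccn23)cc(OC)c1OC`, and compound 2, `COc1cc(C(=O)/C=C/c2c(-c3ccc(F)cc3)nc3ncccn23)cc(OC)c1OC`, share the same enone-linked core and differ in the aromatic group attached to it. In a functional assay on M14 cells (Homo sapiens) for inhibition, read by sulforhodamine B assay, with a stated time of 48 h (a higher number here means a weaker inhibitor of growth, a lower number a stronger inhibitor of growth), compound 1 gives 2080 nM, and in this assay compound 2 gives 2160 nM; compound 2 carries the higher of the two numbers, but the gap to compound 1 lies within the scatter, so the two cannot be told apart.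

Compound 3, `COc1ccc(-c2nc3ncccn3c2/C=C/C(=O)c2cc(OC)c(OC)c(OC)c2)cc1`, has not yet been measured. It differs from compound 2 at a single point: methoxy in place of fluoro on an aromatic carbon. Within the data shown here, no step between measured compounds exists for this change, so the expectation rests only on the closeness of compound 1 and compound 2. The step from compound 2 to compound 3 is expected to be small, a 1.3-fold lower number from compound 2 to compound 3 (0.10 log units; within the scatter), likely within the scatter in either direction. Compound 3 is therefore estimated at 1700 nM, in the range 600 nM to 5000 nM.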

Compound 3, concentration for 50% growth inhibition: 1530 nM
Compound 3: middle estimate off by 1.1-fold (0.05 log units), on the high side, within the range that was stated.
By their numbers in this assay, from the lowest: compounds 3, 1 and 2 (each within the scatter of the next).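

In this assay, among these compounds, the exchange of 4-fluorophenyl for 4-methoxyphenyl gives the first direct reading at this position, and the step is a 1.4-fold lower number from compound 2 to compound 3 (0.15 log units; within the scatter). On this aromatic carbon, para to a large group, methoxy in place of fluoro brings one more heavy atom and a hydrogen-bond acceptor, yet compound 2 and compound 3 cannot be told apart in these cells. No measurement shown offers an explanation for this result.

From the compounds shown here alone, what an amine or a carboxylic acid would do at this carbon remains open, as does the effect of a longer chain such as butoxy in place of methoxy. Going by these compounds, it is also open whether the exchange of fluoro for methoxy would read the same on the core of compound 1.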